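The source may hold more compounds than are shown below. What is called first, only, known or untested is meant among the compounds shown, and "the series" means these compounds.

Of the compounds shown here, three have been measured so far: compound 1 `c1ccc(/N=c2\ssnc2-c2cccs2)cc1`, compound 2 `S=c1ssnc1-c1ccccc1` and compound 3 `O=[N+]([O-])c1ccc(-c2nssc2=S)cc1`, all built on a shared core. In a functional assay on MDA-MB-231 cells (Homo sapiens) for antiproliferative activity, read by MTT assay, with a stated time of 72 h (on this read-out lower numbers stand for stronger inhibition of growth and higher numbers for weaker inhibition of growth), compound 1 gives > 10000 nM, which is a limit of the assay rather than a number. Compound 2 gives > 10000 nM, again a limit. Compound 3 gives > 10000 nM, also a limit. Compound 3 therefore stands at the limit of > 10000 nM in this assay, at which 3 of the 3 values shown sit, together with the two other values shown, and nothing in the numbers places it higher or lower than them. Among the compounds with values here, the one step between measured compounds that differ in a single place, a step that the two limits leave unreadable from compound 2 to compound 3, cannot be read, since both of its ends are limits.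

Compound 4 `Fc1ccc(-c2nssc2=S)cc1` is the compound still to be measured. It differs from compound 3 in one place: fluoro in place of nitro on an aromatic carbon. Within the data shown here, no measured step bears on this particular change, so there is no measured size to carry over. With every value shown sitting at the limit of > 10000 nM in this assay, at which 3 of the 3 values shown sit, the expected step that the limit leaves unreadable from compound 3 to compound 4 is small in either direction, and the most likely outcome is once more a limit. Compound 4 is therefore estimated at 20000 nM, with a range from 5000 nM to 80000 nM.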

Compound 4, concentration for 50% growth inhibition: > 10000 nM
Compound 4: a limit, no number (the forecaster's own chance of this, stated with the estimate: 80%); the middle value lies beyond the limit too.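

Compound 4 gives only a limit, as do compound 2 and compound 3, so neither the change from compound 3 to compound 4 nor that from compound 2 to compound 4 can be read as a step. The compounds shown leave open whether hydrogen, nitro and fluoro differ at all in this assay, and what any of the four actual values is: the limit of > 10000 nM in this assay, at which 4 of the 4 values shown sit.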